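The compounds below may be only part of what the source reports. "The series", "measured", "known", "first", "only" and "open" are said of these compounds alone.

Measured so far in an assay on HEK293 cells for displacement of a labelled ligand from Urotensin-2 receptor (Homo sapiens); a higher number here means a weaker inhibitor, a lower number a stronger inhibitor:
- compound 1 `Cn1ccc2c(NC(=O)NCCN3CCC(O)(Cc4ccccc4)CC3)ccnc21` gives 160 nM
- compound 2 `Cc1cc2nccc(NC(=O)NCCN3CCC(O)(Cc4ccccc4)CC3)c2s1` gives 78 nM
- compound 3 `O=C(NCCN1CCC(O)(Cc2ccccc2)CC1)Nc1ccnc2c(Br)csc12` is not yet measured

For the measured compounds named here, compound 2 stands at the lowest of the two numbers; its nearest neighbour is compound 1, and the step of a 2.1-fold lower number from compound 1 to compound 2 (0.31 log units; beyond the scatter) is the only measured step. That step is a swap of the whole bicyclic group on the amide-type nitrogen, and the change now considered is of the same kind: a group of 10 heavy atoms (7 carbon, 1 nitrogen, 1 sulfur, 1 bromine; one five-membered aromatic ring with 1 hetero atom, one six-membered aromatic ring with 1 hetero atom) in place of a group of 10 heavy atoms (8 carbon, 1 nitrogen, 1 sulfur; one five-membered aromatic ring with 1 hetero atom, one six-membered aromatic ring with 1 hetero atom), on an amide-type nitrogen. Going by the values given here, the one step that bears on it was modest, so a shift in this assay of comparable or smaller size is expected, in either direction, with a real chance of none beyond the scatter. The estimate for compound 3 is therefore set close to compound 2, as a 1.0-fold higher number from compound 2 to compound 3 (0.01 log units; within the scatter), giving an expected value of 80 nM with a range from 30 nM to 250 nM.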

Compound 3, half-maximal inhibitory concentration: 3220 nM
Compound 3: middle estimate off by 40-fold (1.60 log units), on the low side; measured number outside the range, above it.
By their numbers in this assay, from the lowest: compound 2; then compound 1; then compound 3.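

In this assay the group on the amide-type nitrogen proves far less forgiving than the earlier step suggested: the swap gives a 41-fold higher number from compound 2 to compound 3 (1.62 log units; beyond the scatter) and is a large loss, even though both groups have the same heavy-atom count, ring types and hydrogen-bond donor and acceptor counts. The bromine-containing group also compares poorly with the group of compound 1, with a 20-fold higher number from compound 1 to compound 3 (1.30 log units; beyond the scatter) as the step, so changes at this place need not stay modest and these counts do not sort the three groups. No measurement at hand bears on the reason for the loss.

Going by these compounds, it remains open whether the bromine itself or another difference between the groups carries the loss. A chlorine atom or a hydrogen in place of the bromine in compound 3 would test this directly.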